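Cytotoxicity of Aminoquinoline Hydrazides: From Compound 2 to Compound 3

This account rests on a few compounds, and the source may have more. Where it says the series, first, only, none or still open, it means among the compounds named here.

Measured so far:
Compound 1, `COc1cc(NC(C)CCCNC(=O)/C=C/c2ccccc2)c2ncccc2c1`, 18500 nM
Compound 2, `COc1cc(NC(C)CCCNC(=O)NNC(=O)/C=C/c2ccc(OC)c(OC)c2)c2ncccc2c1`, 37000 nM

Of the compounds shown here, two have so far been tested in an ADME assay on L6 cells (Rattus norvegicus) for cytotoxicity, read by resazurin assay, with a stated time of 70 h; a lower number here means a stronger inhibitor, a higher number a weaker inhibitor. Compound 1 gives 18500 nM, and compound 2 gives 37000 nM. Going by the values given here, only these two numbers are known, and the gap between them lies within the scatter of the method, so compound 2 cannot be set apart from compound 1 on this evidence; the two compounds share the same core and differ in the whole acyl part of the side chain, a difference for which no single step is recorded.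

Compound 3, `COc1cc(NC(C)CCCNC(=O)NNC(=O)Nc2ccc(Br)cc2)c2ncccc2c1`, is the next compound to be measured in this assay. It is derived from compound 2 by one change: (4-bromophenyl)amino in place of 2-(3,4-dimethoxyphenyl)ethenyl on a carbonyl carbon.

Among the compounds with values here, no measured pair shows the effect of such an exchange, so the expectation for compound 3 rests on the two values above alone. The step of a 1.2-fold lower number from compound 2 to compound 3 (0.09 log units; within the scatter) is expected to stay within the scatter, with no clear direction. Compound 3 is therefore estimated at 30000 nM, within a range from 12000 nM to 80000 nM.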

Compound 3, half-maximal inhibitory concentration: 38700 nM
Estimate against measurement, compound 3: 1.3-fold (0.11 log units) below; the measured number falls inside the stated range.
By their numbers in this assay, from the lowest: compounds 1, 2 and 3 (each within the scatter of the next, the first and the last beyond it).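

In this assay, the exchange at a carbonyl carbon, where 2-(3,4-dimethoxyphenyl)ethenyl leaves and (4-bromophenyl)amino enters, gives a 1.0-fold higher number from compound 2 to compound 3 (0.02 log units; within the scatter), the first single-place step available in this set. At this position, a group of 12 heavy atoms with a double bond outside aromatic rings and 2 hydrogen-bond acceptors cannot be told apart in this read-out from a group of 8 heavy atoms with a bromine and 1 hydrogen-bond donor, although both carry one six-membered aromatic ring of carbon only. No measurement offered here explains this outcome.

The compounds shown leave open whether this carbonyl carbon would give a step beyond the scatter with a substituent lacking an aromatic ring, such as a methyl group or a simple alkylamine. They also leave open whether a carboxylic acid or a dimethylamino group on the aromatic ring would change the number, and whether the result of this single exchange would hold with a shorter or longer chain joining the shared core to the carbonyl part.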